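A few compounds are considered here, and "the series" means these few. Any claim that something is new, unique, unknown or untested is made for them only; others in the source may bear on it.

Compound 1 `CCCSc1nc(Cl)c2c(n1)N(CC1CCCCC1)C(C(=O)N1CCN(C)CC1)N2`: > 64000 nM
Compound 2 `CCCSc1nc(Cl)c2c(n1)N(Cc1ccccc1)C(C(=O)Nc1ccccc1)N2`: > 64000 nM

In a functional assay on TE-1 cells (Homo sapiens) for antiproliferative activity, read by MTT assay, with a stated time of 72 h (on this read-out higher numbers stand for weaker inhibition and lower numbers for stronger inhibition), compound 1 gives > 64000 nM, which is a limit of the assay and not a number. Compound 2 gives > 64000 nM, likewise a limit. Both sit at the limit of > 64000 nM in this assay, at which 2 of the 2 values shown sit, so compound 1 stands at the edge of what the assay resolves. Compound 3 `CCCSc1nc(Cl)c2c(n1)N(Cc1ccco1)C(C(=O)N1CCN(C)CC1)N2` differs from compound 1 by furan-2-yl in place of cyclohexyl on a saturated chain carbon bound to a nitrogen on an aromatic ring in a ring. Among the measured compounds shown here, no measured step covers this change, and the expectation is none beyond the scatter, with another limit the likeliest outcome. The expected step is a number no higher from compound 1 to compound 3 (the limit leaves the size open). Compound 3 is expected to give 64000 nM, in a range from 20000 nM to 64000 nM.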

Compound 3, half-maximal inhibitory concentration: 35000 nM
For compound 3 the middle estimate is 1.8-fold (0.26 log units) above the measured one; low and high end bracket the measured number.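

Among the compounds shown here, compound 3, at 35000 nM in this assay, gives the first number rather than a limit, so the place on the saturated chain carbon responds to a change. Furan-2-yl in place of cyclohexyl gives an at least 1.8-fold lower number from compound 1 to compound 3 (0.26 log units; that floor lies within the scatter). The true size of that step stays open, since compound 1 has only a limit: the limit of > 64000 nM in this assay, at which 2 of the 3 values shown sit.

The compounds shown leave open whether the furan oxygen matters, which thiophen-2-yl at this place would test. They also leave open whether pyridin-2-yl would give a lower number than compound 3.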